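The compounds below may be only part of what the source reports. "The series", "measured", "known", "first", "only" and "open" are said of these compounds alone.

The measured compounds in a functional assay on MCF7 cells (Homo sapiens), tested at 2.5 uM; on this read-out higher numbers stand for a weaker effect at the one concentration tested and lower numbers for a stronger effect:

- compound 1, `C=CCOc1c(C)c(C)c2c(c1C)CCC(C)(COc1ccc(/C=C3\SC(=O)NC3=O)cc1)O2`: compound 1 gives 45%
- compound 2, `C=CCOc1c(C)c(C)c2c(c1C)CCC(C)(COc1ccc(/C=C3\SC(=O)NC3=O)cc1OC)O2`: compound 2 gives 34%
- compound 3, `CC(C)=CCOc1c(C)c(C)c2c(c1C)CCC(C)(COc1ccc(/C=C3\SC(=O)NC3=O)cc1-c1ccc(F)cc1)O2`: compound 3 gives 87%

Compound 3 stands highest of the three numbers in this assay, beyond the scatter from both compound 1 and compound 2, so it shows the weakest effect at the single concentration tested. Compound 4, `CC(C)=CCOc1c(C)c(C)c2c(c1C)CCC(C)(COc1ccc(/C=C3\SC(=O)NC3=O)cc1Br)O2`, has not yet been measured. It differs from compound 3 at one place: bromo in place of 4-fluorophenyl on an aromatic carbon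

Within the data shown here, only one measured step exists, a number 11 percentage points lower from compound 1 to compound 2 (beyond the scatter), and it concerns a different pair of groups on a different core, so no step in the set bears directly on the present change. What the numbers do show is that the two compounds carrying a small group or hydrogen at that place, compound 1 and compound 2, sit far lower than compound 3, which carries the 4-fluorophenyl there. Compound 4 carries bromo, a single heavy atom, at that place, so a step downward from compound 3 toward the region of compound 1 is expected, though the core of compound 4 matches compound 3 and not compound 1, which leaves the size uncertain. Compound 4 is therefore estimated at 60%, within 35% to 88%, meaning an expected step of a number 27 percentage points lower from compound 3 to compound 4 (beyond the scatter).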

Compound 4, a percentage reported as activity, at one concentration (the size of the read-out at that concentration, not a potency): 96%
Compound 4: middle estimate off by 36 percentage points, on the low side; the measured number lies above the stated range.
By their numbers in this assay, from the lowest: compound 2; then compound 1; then compounds 3 and 4 (each within the scatter of the next).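

In this assay, putting bromo in place of 4-fluorophenyl on this aromatic carbon gives a number 9 percentage points higher from compound 3 to compound 4 (within the scatter), so compound 3 and compound 4 cannot be told apart on this read-out. This is the first step shown at this place, and the only step before it was methoxy in place of hydrogen on the core of compound 1; it shows that, on the core shared by compound 3 and compound 4, a group of 7 heavy atoms with its aromatic ring and a single bromine atom read alike at the one concentration tested. Nothing measured here explains why the two groups read alike.

Compound 1 and compound 2 differ from compound 3 and compound 4 at this place and also in the chain on the other ether oxygen, so the compounds shown leave the share of each of the two places in their numbers unresolved. Also open, going by these compounds, is how hydrogen, methoxy, an amine or a carboxylic acid on this aromatic carbon would read on the core shared by compound 3 and compound 4.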